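Replacing 2-methoxyphenyl with 2,4,6-trifluorophenyl in compound 4

A few compounds are considered here, and "the series" means these few. Any claim that something is new, unique, unknown or untested is made for them only; others in the source may bear on it.

Measured so far in an ADME assay on MDBK cells (Bos taurus) for cytotoxicity, read by MTT assay (on this read-out higher numbers stand for lower toxicity in this test and lower numbers for higher toxicity in this test), are these compounds:
- Compound 1 `CCCC1CCCCC1OCCCCCCN1C[C@H](O)[C@@H](O)[C@H](O)[C@H]1CO` gives 150000 nM
- Compound 2 `CC1CC(OCCCCCCN2C[C@H](O)[C@@H](O)[C@H](O)[C@H]2CO)CC(C)(C)C1` gives 250000 nM
- Compound 3 `COc1ccccc1OCCCCCCN1C[C@H](O)[C@@H](O)[C@H](O)[C@H]1CO` gives > 500000 nM

Compound 3 stands at > 500000 nM in this assay and this is a limit of the assay, not a number. Compound 4 `OC[C@@H]1[C@@H](O)[C@H](O)[C@@H](O)CN1CCCCCCOc1c(F)cc(F)cc1F` carries 2,4,6-trifluorophenyl in place of 2-methoxyphenyl on an oxygen on a saturated carbon and the rest of the molecule stays the same.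

Among the measured compounds shown here, no measured step exchanges one aromatic group for another. The closest evidence comes from the two steps that replace a non-aromatic ring with the aromatic ring of compound 3. The first is an at least 3.3-fold higher number from compound 1 to compound 3 (0.52 log units; beyond the scatter) and the second is an at least 2.0-fold higher number from compound 2 to compound 3 (0.30 log units; that floor lies within the scatter) and only the first clears the scatter. The step between the two non-aromatic rings, a 1.7-fold higher number from compound 1 to compound 2 (0.22 log units; within the scatter) for comparison, stays within it.

Given the size of an at least 3.3-fold higher number from compound 1 to compound 3 (0.52 log units; beyond the scatter) on gaining an aromatic ring, which compound 4 keeps, no step beyond the scatter is expected in this assay and no direction can be favoured. Another report of a limit is quite possible. The expected change is a number no higher from compound 3 to compound 4 (the limit leaves the size open) and that is an estimate only. The estimate for compound 4 is 500000 nM with 220000 nM to 1000000 nM as its expected range.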

Compound 4, half-maximal cytotoxic concentration: > 500000 nM
Compound 4 ended at the assay's limit; the forecaster's own chance of this, stated with the estimate: 55%; the middle value lies on the limit itself.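

In this assay compound 4 gives > 500000 nM, which is a limit of the assay and not a number. Compound 3 stands at the same limit, so the step between them cannot be read, and the exchange of 2-methoxyphenyl for 2,4,6-trifluorophenyl has no measurable size in this test: the limit of > 500000 nM in this assay, at which 2 of the 4 values shown sit.

What the new compound adds is that the place on the oxygen on a saturated carbon now holds a second aromatic group with the read-out still at the limit: against the non-aromatic rings this gives an at least 3.3-fold higher number from compound 1 to compound 4 (0.52 log units; beyond the scatter), which clears the scatter, and an at least 2.0-fold higher number from compound 2 to compound 4 (0.30 log units; that floor lies within the scatter), whose floor does not.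

From the compounds shown here alone, how far beyond the limit either aromatic compound lies stays open, and so does any order between the two. The compounds shown also leave open whether a phenyl ring carrying a carboxylic acid or an amine, or a pyridine ring in its place, would stay at this limit or return a readable number.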